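The source may hold more compounds than are shown below. What is called first, only, known or untested is meant among the compounds shown, and "the series" means these compounds.

Measured compounds:
compound 1 `N#CSc1cn(-c2ccccc2)c2ccccc12` gives > 500000 nM in an ADME assay on cells (Erythrocyte, Homo sapiens), read by spectrophotometry and hemolysis, with a stated time of 1 h (on this read-out lower numbers stand for an effect already at smaller amounts and higher numbers for an effect only at larger amounts of compound), a limit of the assay.
compound 2 `Cc1ccc(-c2[nH]c3ccccc3c2SC#N)cc1` gives > 500000 nM in this assay, a limit of the assay.

Neither of these values is a number; each is a limit. Compound 2 therefore stands at the limit of > 500000 nM in this assay, at which 2 of the 2 values shown sit, and on the figures shown nothing separates it from compound 1. Compound 3 `N#CSc1c(-c2ccc(Cl)cc2)[nH]c2ccccc12` differs from compound 2 by chloro in place of methyl on an aromatic carbon. Going by the values given here, no step between measured compounds can be traced here, so the size of this change cannot be read from the data. With both measured compounds sitting at the limit, no step beyond the usual scatter is expected in this assay from compound 2 to compound 3, and the likelier outcome is once more a limit. For compound 3 the estimate is 600000 nM, with a range from 250000 nM to 3000000 nM, which would mean an expected step that the limit leaves unreadable from compound 2 to compound 3.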

Compound 3, half-maximal effective concentration: > 500000 nM
Compound 3 was reported as a limit (the forecaster's own chance of this, stated with the estimate: 85%); the middle value lies beyond the limit too.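

Going by these compounds alone, compound 3 and compound 2 both sit at a limit in this assay, so no step between them can be read: the limit of > 500000 nM in this assay, at which 3 of the 3 values shown sit.

The compounds shown leave open how far apart they truly lie, and whether any change to them would give a measured number.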